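Chloro Entering the Anilino Ring of Compound 3

The compounds below may be only part of what the source reports. "The series", "measured", "known", "first", "only" and "open" are said of these compounds alone.

Compound 3 `COC(=O)c1c(Nc2ccccc2)sc(C(=O)c2ccc(C)cc2)c1C` gives 8.16% in a functional assay, with a stated time of 150 min, tested at 25 ug/mL (a higher number here means a stronger effect of the compound at the concentration tested, a lower number a weaker effect), the lowest of the three numbers shown. Compound 2 `COC(=O)c1c(Nc2ccc(OC)cc2)sc(C(=O)c2ccc(OC)cc2)c1C` gives 15.5%, a value within the scatter of that of compound 3, while compound 1 `COC(=O)c1c(Nc2ccccc2)sc(C(=O)c2ccc(OC)cc2)c1C` gives 36.9%, beyond the scatter above it. Compound 4 `COC(=O)c1c(Nc2ccc(Cl)cc2)sc(C(=O)c2ccc(C)cc2)c1C` differs from compound 3 by chloro in place of hydrogen on an aromatic carbon. The step of a number 21.4 percentage points lower from compound 1 to compound 2 (beyond the scatter) put a substituent onto the anilino ring and lowered activity; the step of a number 28.7 percentage points lower from compound 1 to compound 3 (beyond the scatter) altered a different ring and lowered it as well. Compound 3 already sits close to the floor of the read-out, leaving little room for a further fall. The expected shift is therefore a number 0.2 percentage points lower from compound 3 to compound 4 (within the scatter), an estimate that stays within the scatter. Compound 4 is expected to give 8%, with a range from 0% to 22%.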

Compound 4, a percentage reported as activity, at one concentration (the size of the read-out at that concentration, not a potency): "not active" (no number reported)
Compound 4 has no reported number here; no gap can be computed for the estimate.
By their numbers in this assay, from the lowest: compounds 3 and 2 (each within the scatter of the next); then compound 1.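

Within the data shown here, compound 4 is reported as "not active" in this assay without a number, so no step from compound 3 can be read. No further data bear on this result. The compounds shown leave open what chloro on the anilino ring would do in the setting of compound 1.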